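The source may hold more compounds than are shown below. What is called first, only, known or untested is meant among the compounds shown, and "the series" means these compounds.

In an ADME assay on microsomes from liver (Homo sapiens) for pharmacokinetics (a higher number here means faster removal of the compound, a lower number slower removal), compound 1 (`Cc1c(Nc2nc(N)c3c(C#N)c(N4CCC[C@H]4C)n(C)c3n2)cnn1[C@H]1CCOC1`) gives 23.3 mL/min/kg while compound 2 (`Cc1c(Nc2nc(N)c3c(C#N)c(N4CCC[C@H]4C)n(C)c3n2)cnn1CC1(O)COC1`) gives 35 mL/min/kg and compound 3 (`Cc1nn(CC(C)(C)O)cc1Nc1nc(N)c2c(C#N)c(N3CCC[C@H]3C)n(C)c2n1`) gives 50 mL/min/kg as the highest of the three numbers, within the scatter of compound 2 but beyond it for compound 1. Compound 4 (`Cc1nn(C)cc1Nc1nc(N)c2c(C#N)c(N3CCC[C@H]3C)n(C)c2n1`) has hydrogen in place of 1-hydroxy-1-methylethyl on a saturated chain carbon bound to an aromatic nitrogen. For the measured compounds named here, the one measured step that also swaps a group on an aromatic nitrogen is a 1.5-fold higher number from compound 1 to compound 2 (0.18 log units; within the scatter) and offers only a weak guide. No step beyond the scatter is therefore expected in this assay for this change. The estimated step is a 1.4-fold lower number from compound 3 to compound 4 (0.14 log units; within the scatter) in a modest downward direction. Compound 4 is expected at 36 mL/min/kg within a range from 18 mL/min/kg to 70 mL/min/kg in this estimate.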

Compound 4, clearance: 70 mL/min/kg
The estimate for compound 4 lay 1.9-fold (0.29 log units) below the measured number; the measured number falls inside the stated range.
By their numbers in this assay, from the lowest: compounds 1, 2, 3 and 4 (each within the scatter of the next, the first and the last beyond it).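

In this assay, for the compounds shown here, replacing 2-hydroxy-2-methylpropyl with methyl gives a 1.4-fold higher number from compound 3 to compound 4 (0.15 log units; within the scatter), so the loss of 1-hydroxy-1-methylethyl produces no step that can be told apart from repeat scatter. Unlike the earlier compounds, compound 4 has no oxygen in the group at this position, and its number still stays within the scatter of compound 3. Nothing available explains this result. Still open, from the compounds shown here alone, is whether an ethyl group, a longer plain carbon chain, an amine or a carboxylic acid at this position would produce a step beyond the scatter.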